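Swapping Trifluoromethyl for Tert-Butyl: Solubility Outlook

This account rests on a few compounds, and the source may have more. Where it says the series, first, only, none or still open, it means among the compounds named here.

Of the compounds shown here, two have been measured in a physicochemical assay for solubility, with a stated time of 18 h, at pH 7.4; on this read-out higher numbers stand for higher solubility and lower numbers for lower solubility. Compound 1 `COc1cccc(CNCCCNc2ccnc3cc(C4CCCCC4)ccc23)c1O` gives 4200 nM in this assay. Compound 2 `FC(F)(F)c1ccc(-c2ccc3c(NCCCNCc4ccco4)ccnc3c2)cc1` gives 32000 nM in this assay, the higher of the two numbers, with compound 1 the nearest at a gap beyond the scatter. Compound 3 `CC(C)(C)c1ccc(-c2ccc3c(NCCCNCc4ccco4)ccnc3c2)cc1` has not yet been measured. It differs from compound 2 in one place: tert-butyl in place of trifluoromethyl on an aromatic carbon. For the measured compounds named here, no measured pair shows this change. The step is expected to stay within the scatter, a 1.6-fold lower number from compound 2 to compound 3 (0.20 log units; within the scatter), in no clear direction. Compound 3 is estimated at 20000 nM in this assay, within 6000 nM to 60000 nM.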

Compound 3, solubility: 32000 nM
For compound 3 the middle estimate is 1.6-fold (0.20 log units) below the measured one; the range from low to high includes it.
By their numbers in this assay, from the lowest: compound 1; then compounds 2 and 3 (each within the scatter of the next).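

In this assay, for the compounds shown here, tert-butyl in place of trifluoromethyl on this aromatic carbon shows no change at the digits printed from compound 2 to compound 3 (within the scatter), a reading that the earlier compounds, which held no pair differing in one place, could not give. This position, para to a large group, therefore holds either of these two groups, each of 4 heavy atoms, with no shift beyond the scatter. Nothing shown here explains this match. Going by these compounds, whether an amine or a carboxylic acid at this position would move the number stays open. So does whether these two groups would match on a different core.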